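A few compounds are considered here, and "the series" means these few. Any claim that something is new, unique, unknown or untested is made for them only; others in the source may bear on it.

Measured compounds:
`NS(=O)(=O)c1ccc(N2N=C(c3ccc(Oc4ccccc4)cc3)CC2c2ccc(Cl)cc2)cc1` compound 1: 7000 nM
`Cc1ccc(C2CC(c3ccc(OCc4ccccc4)cc3)=NN2c2ccc(S(N)(=O)=O)cc2)cc1` compound 2: 32000 nM
`NS(=O)(=O)c1ccc(N2N=C(c3ccc(Oc4ccccc4)cc3)CC2c2cccc(Cl)c2)cc1` compound 3: 9000 nM

In an ADME assay on BHK-21 cells (Mesocricetus auratus) for cytotoxicity, read by MTT assay, with a stated time of 72 h (on this read-out lower numbers stand for higher toxicity in this test and higher numbers for lower toxicity in this test), compound 3 gives the second highest of the three numbers; compound 1 lies nearest to it, within the scatter, and compound 2 lies furthest, beyond the scatter. Compound 4 `Cc1ccc(C2CC(c3ccc(Oc4ccccc4)cc3)=NN2c2ccc(S(N)(=O)=O)cc2)cc1` is not yet measured. It differs from compound 3 by 4-methylphenyl in place of 3-chlorophenyl on a saturated ring carbon. Going by the values given here, the only single-point step measured so far, a 1.3-fold higher number from compound 1 to compound 3 (0.11 log units; within the scatter), stayed within the scatter. Compound 2 also carries a 4-methylphenyl but differs from compound 3 in a second place as well, so its higher number can only be noted, not used as a step. Among the compounds with values here, no measured step matches this change directly. The step to compound 4 is therefore expected to be modest and upward, a 1.4-fold higher number from compound 3 to compound 4 (0.16 log units; within the scatter). Compound 4 is estimated at 13000 nM, with a range from 5000 nM to 32000 nM.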

Compound 4, half-maximal cytotoxic concentration: 8000 nM
Estimate against measurement, compound 4: 1.6-fold (0.21 log units) above; measured number inside the range.
By their numbers in this assay, from the lowest: compounds 1, 4 and 3 (each within the scatter of the next); then compound 2.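

In this assay, the saturated ring carbon shows no separation between 4-methylphenyl and 3-chlorophenyl, with a 1.1-fold lower number from compound 3 to compound 4 (0.05 log units; within the scatter) within the scatter, and methyl in place of chloro on an aromatic carbon gives a 1.1-fold higher number from compound 1 to compound 4 (0.06 log units; within the scatter), also within the scatter. Going by these compounds alone, the one step beyond the scatter lies at the other end of the molecule, where phenyl in place of benzyl on an oxygen gives a 4.0-fold lower number from compound 2 to compound 4 (0.60 log units; beyond the scatter) as the change. No measurement shown here explains these steps.

Still open, from the compounds shown here alone, is whether an amine or a carboxylic acid on the aromatic ring at the saturated carbon would move the number. Also open, going by these compounds, is whether the benzyl-to-phenyl step holds with a chlorophenyl group on that carbon.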